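The source may hold more compounds than are shown below. What is called first, only, known or untested is meant among the compounds shown, and "the series" means these compounds.

Three compounds have been measured in an ADME assay on the whole organism (plasma, strain Sprague-Dawley) for pharmacokinetics, with Rattus norvegicus as the target, with stated times of 6 h and 30 min, at a dose of 10 mg/kg by the oral route; a higher number here means more compound in the circulation at the dose given, a lower number less compound in the circulation:

compound 1, `Cc1cc2c(cc1F)c(C(N)=O)c(-c1ccc(NS(=O)(=O)C(C)(C)C)cc1)n2C1CCCC1`, gives 216 ng.h/mL
compound 2, `CC(C)(C)S(=O)(=O)Nc1ccc(-c2c(C(N)=O)c3cc(F)c(OC(F)F)cc3n2C2CCCC2)cc1`, gives 200 ng.h/mL
compound 3, `Cc1cc2c(cc1F)c(C(N)=O)c(-c1ccc(NS(=O)(=O)C(C)(C)C)cc1)n2C1CCCCC1`, gives 333 ng.h/mL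

Compound 1 and compound 2 differ in one place, (difluoromethoxy in place of methyl on an aromatic carbon), and this change made a step of a 1.1-fold lower number from compound 1 to compound 2 (0.03 log units; within the scatter). Compound 1 and compound 3 differ in the core, (cyclohexyl in place of cyclopentyl on an aromatic nitrogen), with a step of a 1.5-fold higher number from compound 1 to compound 3 (0.19 log units; within the scatter). All three values therefore sit close together, and none can be called higher or lower than another with confidence.

Compound 4, `CC(C)(C)S(=O)(=O)Nc1ccc(-c2c(C(N)=O)c3cc(F)c(OC(F)F)cc3n2C2CCCCC2)cc1`, has not yet been measured. It differs from compound 3 by difluoromethoxy in place of methyl on an aromatic carbon, which is the same change that led from compound 1 to compound 2, since the surroundings of the place match word for word. Because compound 3 gives 333 ng.h/mL and the earlier step was a 1.1-fold lower number from compound 1 to compound 2 (0.03 log units; within the scatter), the expected step here is a 1.1-fold lower number from compound 3 to compound 4 (0.05 log units; within the scatter), a small one in the same direction. The estimate for compound 4 in this assay is 300 ng.h/mL, expected to fall between 150 ng.h/mL and 600 ng.h/mL.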

Compound 4, area under the concentration-time curve: 447 ng.h/mL
Beside the measured number, compound 4's estimate is 1.5-fold (0.17 log units) below it; the measured number falls inside the stated range.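

In this assay difluoromethoxy in place of methyl gave a 1.3-fold higher number from compound 3 to compound 4 (0.13 log units; within the scatter) and this matches what the same change did on the core carrying cyclopentyl: the same change on two cores in this assay, a 1.1-fold lower number (0.03 log units; within the scatter) from compound 1 to compound 2 and a 1.3-fold higher number (0.13 log units; within the scatter) from compound 3 to compound 4, 1.4-fold (0.16 log units) apart, within the scatter of two such steps. Cyclohexyl in place of cyclopentyl gave a 2.2-fold higher number from compound 2 to compound 4 (0.35 log units; beyond the scatter) and this also matches its earlier step: the same change on two cores in this assay, a 1.5-fold higher number (0.19 log units; within the scatter) from compound 1 to compound 3 and a 2.2-fold higher number (0.35 log units; beyond the scatter) from compound 2 to compound 4, 1.4-fold (0.16 log units) apart, within the scatter of two such steps. Going by these compounds alone, each change therefore carried from one core to the other without a detectable difference, but this rests on only two pairs per change, and most of the steps are too small to show that the change moves the number at all.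

The compounds shown leave open whether the same holds for other groups on the aromatic carbon, such as a methoxy group or a nitrile, or on the aromatic nitrogen, such as cyclobutyl or a longer chain. They also leave open what an amine or a carboxylic acid elsewhere on the shared core would do to the amount of compound in the circulation.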